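Swapping Chloro for Fluoro on a Weak Antiproliferative Pair

The compounds below may be only part of what the source reports. "The series", "measured", "known", "first", "only" and "open" are said of these compounds alone.

Measured compounds:
- compound 1, `CCCSc1nc(N/N=C/c2ccccc2Cl)c2nnn(Cc3ccccc3)c2n1`: 6180 nM
- compound 2, `CCCSc1nc(N/N=C/c2cc(OC)c(OC)c(OC)c2)c2nnn(Cc3ccccc3)c2n1`: 4060 nM

Of the compounds shown here, two have been tested in a functional assay on ECa-109 cells (Homo sapiens) for antiproliferative activity, read by MTT assay, with a stated time of 72 h; on this read-out lower numbers stand for stronger inhibition and higher numbers for weaker inhibition. Compound 1 gives 6180 nM in this assay, which is the higher of the two numbers; compound 2 gives 4060 nM. The gap between them is within the scatter of repeated measurements, so the two values cannot be told apart, and neither compound can be called the more potent. For the measured compounds named here, no step between measured compounds is available for judging how a small change at this position affects the read-out.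

Compound 3, `CCCSc1nc(N/N=C/c2ccccc2F)c2nnn(Cc3ccccc3)c2n1`, has not yet been measured. It differs from compound 1 by a single exchange: fluoro in place of chloro on an aromatic carbon

Going by the values given here, with only two weak and indistinguishable values in hand, there is no basis for expecting a sizeable move in either direction. The step from compound 1 to compound 3 is expected to stay within the scatter, a 1.1-fold higher number from compound 1 to compound 3 (0.05 log units; within the scatter), with a slight lean toward a higher number. Compound 3 is therefore estimated at 7000 nM in this assay, within a range of 3000 nM to 16000 nM.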

Compound 3, half-maximal inhibitory concentration: > 64000 nM
Compound 3: a limit, no number; the forecaster's own chance of this, stated with the estimate: 10%; at least 9.1-fold (0.96 log units) between middle value and limit.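

In this assay, exchanging one halogen atom on the 2-chlorophenyl group proves to be no small change: an at least 10-fold higher number from compound 1 to compound 3 (1.01 log units; beyond the scatter). The result for compound 3 is a limit of the assay and not a number: the limit of > 64000 nM in this assay, at which 1 of the 3 values shown sits. The earlier compounds shown here could not show this, as they differ in more than one place and their values lie within the scatter of each other; this step shows that activity can depend heavily on which halogen sits on an aromatic carbon ortho to a large group, even though the exchange leaves the ring, the hydrogen-bond donor and acceptor counts and the net charge as they were.

On these data alone, what remains open is whether chloro is specifically favoured here or fluoro is specifically harmful, a question that a bromo group, a methyl group, an amine or plain hydrogen at this place would help to settle. As far as these compounds go, it is also open whether the same exchange would have so large an effect at another place on the ring or with a different chain on the sulfur.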